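The source may hold more compounds than are shown below. What is called first, only, known or untested is meant among the compounds shown, and "the series" means these compounds.

Measured compounds: compound 2 `CC(C)C[C@@H](CO)Nc1ncnc2c1ncn2C1O[C@H](CO)[C@@H](O)[C@H]1O` with 139 nM in an assay on membranes from brain for binding affinity to adenosine receptor A1 (Rattus norvegicus); on this read-out higher numbers stand for weaker inhibition and lower numbers for stronger inhibition; compound 1 `OC[C@H]1OC(n2cnc3c(NN4CCOCC4)ncnc32)[C@H](O)[C@@H]1O` with 15500 nM in this assay.

For the measured compounds named here, compound 2 holds the lowest of the two numbers; the one step recorded, a 110-fold lower number from compound 1 to compound 2 (2.05 log units; beyond the scatter), separates it from compound 1. Compound 3 `CC(C)C[C@H](CO)Nc1ncnc2c1ncn2C1O[C@H](CO)[C@@H](O)[C@H]1O` differs from compound 2 in this way: the two compounds have the same atoms and bonds; at least one stereo element is drawn with a configuration in one of them and without one in the other: 1 of 5 stereo elements differ; a stereocentre at a saturated chain carbon is drawn S in compound 2 and R in compound 3. Going by the values given here, no measured step touches a change of configuration, and the step from compound 1 to compound 2 concerns a different change, so nothing here sets the size or direction of the change for compound 3. For compound 3 the expected step is estimated as a 2.9-fold higher number from compound 2 to compound 3 (0.46 log units; beyond the scatter). Compound 3 is estimated at 400 nM, in the range 50 nM to 4000 nM.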

Compound 3, inhibition constant: 224 nM
Compound 3: middle estimate off by 1.8-fold (0.25 log units), on the high side, and the stated range covers the measured number.
By their numbers in this assay, from the lowest: compounds 2 and 3 (each within the scatter of the next); then compound 1.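

At the saturated chain carbon, the S and R drawings are not separated in this assay, with a 1.6-fold higher number from compound 2 to compound 3 (0.21 log units; within the scatter) as the whole gap. The 1-(hydroxymethyl)-3-methylbutyl group in place of morpholin-4-yl still gives a 69-fold lower number from compound 1 to compound 3 (1.84 log units; beyond the scatter) with the R drawing, so the large step does not rest on the S drawing alone. One caveat applies to this reading of the configuration: the fact that one of compounds 2 and 3 is drawn with a defined configuration and the other without, at the place where they differ.

Open, going by these compounds, is whether a longer chain, or a carboxylic acid in place of the hydroxymethyl, would stay close to compound 2 and compound 3.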